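A few compounds are considered here, and "the series" means these few. Any claim that something is new, unique, unknown or untested is made for them only; others in the source may bear on it.

compound 1 `O=S(=O)(Nc1ncccn1)c1ccc2c(c1)OCC[C@@H]2c1ccc(C(F)(F)F)cc1-c1ccc(F)nc1`: 6370 ng.h/mL
compound 2 `Cn1nccc1-c1cc(C(F)(F)F)ccc1[C@H]1CCOc2cc(S(=O)(=O)Nc3ncccn3)ccc21`: 6190 ng.h/mL
compound 3 `Cn1nccc1-c1cc(C(F)(F)F)ccc1[C@H]1CCc2cc(S(=O)(=O)Nc3ncccn3)ccc21`: 4250 ng.h/mL

In an ADME assay on the whole organism (Mus musculus, strain BALB/c), read by LC-MS, with a stated time of 24 h, at a dose of 1 mg/kg by the intravenous route (a lower number here means less compound in the circulation, a higher number more compound in the circulation at the dose given), compound 1 at 6370 ng.h/mL stands level with compound 2 and compound 3, all within the scatter. Compound 4 `O=S(=O)(Nc1nccs1)c1ccc2c(c1)OCC[C@@H]2c1ccc(C(F)(F)F)cc1-c1ccc(F)nc1` differs from compound 1 by 1,3-thiazol-2-yl in place of pyrimidin-2-yl on a sulfonamide nitrogen. Among the measured compounds shown here, the one measured step, a 1.0-fold lower number from compound 1 to compound 2 (0.01 log units; within the scatter), lies within the scatter, but it falls on an aromatic carbon. For the measured compounds named here, no measured compound alters the group on the sulfonamide nitrogen, so the data bear on this change only indirectly. The expected size is a 1.4-fold lower number from compound 1 to compound 4 (0.15 log units; within the scatter), so no change beyond the scatter is expected. For compound 4 the estimated value is 4500 ng.h/mL, with an expected range of 1800 ng.h/mL to 9500 ng.h/mL.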

Compound 4, area under the concentration-time curve: 1070 ng.h/mL
Compound 4: middle estimate off by 4.2-fold (0.62 log units), on the high side; the whole stated range lies above it.
By their numbers in this assay, from the lowest: compound 4; then compounds 3, 2 and 1 (each within the scatter of the next).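

In this assay the group on a sulfonamide nitrogen proves to be a place where one change counts: 1,3-thiazol-2-yl in place of pyrimidin-2-yl gives a 6.0-fold lower number from compound 1 to compound 4 (0.77 log units; beyond the scatter) here, whereas the change on an aromatic carbon gave a 1.0-fold lower number from compound 1 to compound 2 (0.01 log units; within the scatter) and stayed level. Nothing at hand accounts for this drop.

Still open, on these data alone, is whether the lower number follows the 1,3-thiazol-2-yl group onto the core of compound 2. Also open, as far as these compounds go, is what a pyridin-2-yl or a plain methyl on the sulfonamide nitrogen would give.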